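A few compounds are considered here, and "the series" means these few. Any claim that something is new, unique, unknown or untested is made for them only; others in the source may bear on it.

The measured compounds and their values in a functional assay, with a stated time of 30 min, in the absence of a further agent; on this read-out lower numbers stand for stronger inhibition and higher numbers for weaker inhibition:

compound 1 `O=C(Nc1nnc(-c2cccc(O)c2O)s1)c1ccccc1`, in this assay 22300 nM
compound 2 `CC(=O)Nc1nnc(-c2cccc(O)c2O)s1`, in this assay 111000 nM
compound 3 `CC(=O)Nc1nnc(-c2ccc(O)c(O)c2)s1`, in this assay 23400 nM

Of the compounds shown here, three have been measured in this assay so far, and a fourth, compound 4 `O=C(Nc1nnc(-c2ccc(O)c(O)c2)s1)c1ccccc1`, has not. Compound 1 and compound 2 share a core and differ in one place: phenyl in place of methyl on a carbonyl carbon. That change made a 5.0-fold lower number from compound 2 to compound 1 (0.70 log units; beyond the scatter). Compound 3 carries the same atoms as compound 2 joined differently; the difference between the two cores is not broken down here. In this assay compound 3 stands close to compound 1, within the usual scatter, while compound 2 stands beyond the scatter from both.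

Compound 4 stands to compound 3 as compound 1 stands to compound 2: phenyl in place of methyl on a carbonyl carbon. Among these compounds this change occurs twice, and only once with both ends measured. The expectation for compound 4 rests on that one measured step and on the value of compound 3, 23400 nM, as its starting point. A step of about a 5.0-fold lower number from compound 3 to compound 4 (0.70 log units; beyond the scatter) is expected, because the same change made a 5.0-fold lower number from compound 2 to compound 1 (0.70 log units; beyond the scatter). Compound 4 is therefore estimated to give 4700 nM in this assay. Compound 4 is expected to fall between 2000 nM and 12000 nM, the wider range reflecting that the step is known from a single pair only.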

Compound 4, half-maximal inhibitory concentration: 23400 nM
The estimate for compound 4 lay 5.0-fold (0.70 log units) below the measured number; the measured number lies above the stated range.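

In this assay, phenyl in place of methyl on a carbonyl carbon gave no change at the digits printed from compound 3 to compound 4 (within the scatter), so the gain seen on the core of compound 2 did not reappear on the core of compound 3. The size of this change therefore cannot be taken from one of these cores and applied to the other, even though the two cores carry the same atoms joined differently, and the two steps clearly differ: the same change on two cores in this assay, a 5.0-fold lower number (0.70 log units; beyond the scatter) from compound 2 to compound 1 and no change at the digits printed (within the scatter) from compound 3 to compound 4, 5.0-fold (0.70 log units) apart, beyond the scatter of two such steps. Going by these compounds alone, this shows that the step depends on the core in this small set, but it rests on only two pairs and does not show why the cores differ, nor what the change would do on any further core.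

The compounds shown leave open how a group other than methyl or phenyl on that carbonyl carbon, such as a longer chain or an amine, would behave on either core. Equally open, as far as these compounds go, is how the same change would run on a core with methoxy groups in place of the two hydroxyl groups.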